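The compounds below may be only part of what the source reports. "The series", "measured", "known", "first", "only" and "open" are said of these compounds alone.

Working notes on the series. Three compounds carry a number in a physicochemical assay for lipophilicity, using the shake flask method (a higher number here means a more lipophilic compound, a lower number a more polar compound), so far. Compound 1, `C[C@H](Oc1ccc2ncc(/C=C/C(=O)O)c(C3CC3)c2c1)c1c(Cl)ccc(N)c1Cl`, gives 2.8 in this assay. Compound 2, `C[C@H](Oc1ccc2ncc(S(=O)(=O)CC(=O)O)c(C3CC3)c2c1)c1c(Cl)ccc(F)c1Cl`, gives 2.5 in this assay. Compound 3, `C[C@H](Oc1ccc2ncc(/C=C/C(=O)O)c(N(C)C)c2c1)c1c(Cl)ccc(F)c1Cl`, gives 3.6 in this assay, the highest of the three numbers: compound 1 sits nearest to it, lower by more than the scatter, and compound 2 sits furthest from it, also lower by more than the scatter. No pair among these three differs in a single place, so no single step can be read from them.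

Compound 4, `C[C@H](Oc1ccc2ncc(/C=C/C(=O)O)c(C3CC3)c2c1)c1c(Cl)ccc(F)c1Cl`, is the next compound to go into this assay. Its change from compound 3 is cyclopropyl in place of dimethylamino on an aromatic carbon. The distribution coefficient for compound 4 is expected to come out at 3.7, with a range of 3.2 to 4.2. For the measured compounds named here, the step of a number 0.10 log units higher from compound 3 to compound 4 (within the scatter) that this estimate means is expected to stay within the scatter of repeated measurements, in the upward direction if anything; with no measured step between compounds differing only at this carbon, the number for compound 3, 3.6, is the only anchor, and the value of compound 4 itself remains to be seen.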

Compound 4, distribution coefficient: 4.1
For compound 4 the middle estimate is 0.40 log units below the measured one, and the stated range covers the measured number.
By their numbers in this assay, from the lowest: compounds 2 and 1 (each within the scatter of the next); then compound 3; then compound 4.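

In this assay the aromatic carbon opposite the ring nitrogen now has a readable step: with the rest of the structure unchanged, cyclopropyl in place of dimethylamino gives a number 0.50 log units higher from compound 3 to compound 4 (beyond the scatter), so two groups with the same heavy-atom count do not read alike at this carbon. Compound 4 also links the two earlier compounds to the series through single changes elsewhere, with 2-carboxyethenyl in place of (carboxymethyl)sulfonyl giving a number 1.60 log units higher from compound 2 to compound 4 (beyond the scatter) and fluoro in place of amino giving a number 1.30 log units higher from compound 1 to compound 4 (beyond the scatter), each printed as large where the step at the cyclopropyl carbon is printed as modest. Nothing measured alongside these numbers bears on what lies behind the size of any of the three steps.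

As far as these compounds go, each step rests on a single pair, so it stays open whether cyclopropyl in place of dimethylamino keeps its size when amino stands in place of fluoro or (carboxymethyl)sulfonyl in place of 2-carboxyethenyl. Also open, from the compounds shown here alone, is where a methoxy group, a nitrile or a longer alkyl chain on this same carbon would stand in this assay against cyclopropyl and dimethylamino.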